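The source may hold more compounds than are shown below. What is called first, only, known or untested is meant among the compounds shown, and "the series" means these compounds.

Four compounds share a core carrying a sulfur-rich side chain that ends in a thiocarbonyl carbon, and they are compared in a functional assay on SW480 cells (Homo sapiens) for antiproliferative activity, read by MTT assay, with a stated time of 72 h; on this read-out higher numbers stand for weaker inhibition and lower numbers for stronger inhibition. Compound 1 `O=c1cc(CSC(=S)N2CCCCC2)oc2cc(Cl)ccc12` gives 2500 nM in this assay. Compound 2 `COc1ccc2oc(CSC(=S)N(C(C)C)C(C)C)cc(=O)c2c1` carries a different core, and in this assay compound 2 gives 7200 nM. Compound 3 `CC(C)N(C(=S)SCc1cc(=O)c2ccc(Cl)cc2o1)C(C)C` reaches only the boundary of this assay, > 25000 nM, which is a limit and not a number. Compound 3 and compound 1 share the same core and differ in one place, (piperidin-1-yl in place of diisopropylamino on a thiocarbonyl carbon), and the step is an at least 10-fold lower number from compound 3 to compound 1 (1.00 log units; beyond the scatter); its size is known only as a lower bound because the limit of > 25000 nM in this assay, at which 1 of the 3 values shown sits, caps what this assay can report. Compound 4 `COc1ccc2oc(CSC(=S)N3CCCCC3)cc(=O)c2c1` is not yet measured; it stands to compound 2 as compound 1 stands to compound 3, the same change, (piperidin-1-yl in place of diisopropylamino on a thiocarbonyl carbon). The difference between the core of compound 2 and the core of compound 3 is not broken down here. The expected step is a 7.2-fold lower number from compound 2 to compound 4 (0.86 log units; beyond the scatter), which rests on an at least 10-fold lower number from compound 3 to compound 1 (1.00 log units; beyond the scatter). Compound 4 is therefore expected to give 1000 nM in this assay, with a likely range from 300 nM to 4000 nM.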

Compound 4, half-maximal inhibitory concentration: 2300 nM
Compound 4: the middle estimate sits 2.3-fold (0.36 log units) below what was measured, and the stated range covers the measured number.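

In this assay, piperidin-1-yl in place of diisopropylamino again gives a lower number, a 3.1-fold lower number from compound 2 to compound 4 (0.50 log units; beyond the scatter), so the change points the same way on both cores shown. Its size, however, does not carry over unchanged from one core to the other: the same change on two cores in this assay, an at least 10-fold lower number (1.00 log units; beyond the scatter) from compound 3 to compound 1 and a 3.1-fold lower number (0.50 log units; beyond the scatter) from compound 2 to compound 4, at least 3.1-fold (0.50 log units) apart, beyond the scatter of two such steps. On these data alone, compound 3 stands at a limit and not at a number, so the earlier step is known only as a lower bound, and the true gap between the two steps remains unknown: the limit of > 25000 nM in this assay, at which 1 of the 4 values shown sits.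

Two cores are too few to set a rule for the whole series, and these compounds do not show how the change would behave on a third core. As far as these compounds go, it also remains open whether another group on the thiocarbonyl carbon, such as pyrrolidin-1-yl, morpholin-4-yl or dimethylamino, would give numbers closer to those with piperidin-1-yl or to those with diisopropylamino.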